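A few compounds are considered here, and "the series" means these few. Any claim that something is new, unique, unknown or untested is made for them only; others in the source may bear on it.

Measured compounds:

Compound 1, `CN1CC(=O)N(C)c2cnc(Nc3ccc(S(N)(=O)=O)cc3)nc21`: in an assay on Sf9 cells for inhibition of serine/threonine-protein kinase 4 (Homo sapiens), read by luminescence and ADP-Glo, with a stated time of 1 h, in the presence of a further agent that is not named here (a higher number here means a weaker inhibitor, a lower number a stronger inhibitor), compound 1 gives 495 nM.
Compound 2, `CN1C(=O)C(c2ccccc2Br)N(C)c2nc(Nc3ccc(S(N)(=O)=O)cc3)ncc21`: in this assay compound 2 gives 57 nM.

Compound 2 stands lowest of the two numbers; its nearest neighbour is compound 1, and the step of an 8.7-fold lower number from compound 1 to compound 2 (0.94 log units; beyond the scatter) is the only one measured so far. It came from putting a 2-bromophenyl group onto a saturated ring carbon of the shared core where compound 1 carries hydrogen.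

Compound 3, `CN1C(=O)C(Cc2ccccc2)N(C)c2nc(Nc3ccc(S(N)(=O)=O)cc3)ncc21`, is the next case. Compared with compound 2 the change is benzyl in place of 2-bromophenyl on a saturated ring carbon. Going by the values given here, the single measured step bears on it only indirectly: it shows that a seven-heavy-atom aromatic group at this carbon is tied to a lower number than hydrogen, but it gives no reading on swapping one such group for another. Both groups bring one six-membered aromatic ring of carbon only and the same heavy-atom count, so no step beyond the scatter is expected, with a slight lean toward a higher number; the expected step is a 1.9-fold higher number from compound 2 to compound 3 (0.29 log units; within the scatter). For compound 3 in this assay the estimate is 110 nM, with a range from 35 nM to 400 nM.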

Compound 3, half-maximal inhibitory concentration: > 10000 nM
Compound 3 gave a limit, no number (the forecaster's own chance of this, stated with the estimate: 2%); middle value at least 90-fold (1.95 log units) from the limit.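

Compound 3 gives only a limit in this assay, not a number: the limit of > 10000 nM in this assay, at which 1 of the 3 values shown sits. At this saturated ring carbon, 2-bromophenyl and benzyl have the same heavy-atom count and each brings one six-membered aromatic ring of carbon only, yet the step is an at least 170-fold higher number from compound 2 to compound 3 (2.24 log units; beyond the scatter), so the reading depends on which of these groups sits there and not merely on an aromatic ring being present. Against hydrogen the two groups also part ways: 2-bromophenyl gave an 8.7-fold lower number from compound 1 to compound 2 (0.94 log units; beyond the scatter), whereas benzyl gave an at least 20-fold higher number from compound 1 to compound 3 (1.30 log units; beyond the scatter), so a group at this carbon can move the number in either direction.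

The compounds shown do not separate the loss of the bromine from the carbon link that benzyl places between the ring and the saturated ring carbon, a question that plain phenyl and 2-bromobenzyl would address. They also leave open how far the value of compound 3 lies past its limit and how smaller groups at this carbon, such as methyl or an aminomethyl chain, would read.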